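Adding a Phenyl Ring: What to Expect for Compound 3

The source may report more compounds than this note shows. Statements on the series, on what has been measured and on what is new or still open speak of the compounds shown alone.

Two compounds have so far been measured in an assay on CHO cells for binding affinity to metabotropic glutamate receptor 2 (Rattus norvegicus); a higher number here means a weaker inhibitor, a lower number a stronger inhibitor:

compound 1 `N[C@]1(C(=O)O)[C@H]2[C@@H](C[C@H]1OCc1ccccc1)[C@]2(F)C(=O)O`: 7.14 nM
compound 2 `N[C@]1(C(=O)O)[C@H]2[C@@H](C[C@H]1OCc1cccc(-c3ccccc3)c1)[C@]2(F)C(=O)O`: 9.34 nM

Compound 1 has the lowest of the two numbers, but compound 2 lies only a 1.3-fold higher number from compound 1 to compound 2 (0.12 log units; within the scatter) away, a gap that falls within the scatter of repeated measurements, so the two cannot be ranked against each other.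

Compound 3 `N[C@]1(C(=O)O)[C@H]2[C@@H](C[C@H]1OCc1ccc(-c3ccccc3)cc1)[C@]2(F)C(=O)O` has not yet been measured. It differs from compound 1 by phenyl in place of hydrogen on an aromatic carbon. Among the measured compounds shown here, only one measured step bears on this change: the one from compound 1 to compound 2, which also adds a phenyl group to the same aromatic ring of the shared core, placed differently on it. That step was a 1.3-fold higher number from compound 1 to compound 2 (0.12 log units; within the scatter), within the scatter. With a single comparable step showing essentially no movement, the phenyl group in compound 3 is expected to leave the number about where compound 1 stands, perhaps nudging it slightly higher, but not beyond the scatter. Compound 3 is therefore expected to give about 10 nM in this assay, most likely between 4 nM and 30 nM. This corresponds to an expected 1.4-fold higher number from compound 1 to compound 3 (0.15 log units; within the scatter).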

Compound 3, inhibition constant: 25.6 nM
Compound 3: middle estimate off by 2.6-fold (0.41 log units), on the low side; low and high end bracket the measured number.
By their numbers in this assay, from the lowest: compounds 1 and 2 (each within the scatter of the next); then compound 3.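

In this assay, phenyl in place of hydrogen on an aromatic carbon turns out not to behave the same way everywhere on the ring: para to a large group, it gives a 3.6-fold higher number from compound 1 to compound 3 (0.55 log units; beyond the scatter), whereas the placement in compound 2 gave a 1.3-fold higher number from compound 1 to compound 2 (0.12 log units; within the scatter). Among these three compounds, then, the position of the phenyl matters, and the position para to a large group is the one where adding it produces a change that can be told apart from the scatter, though a modest one. Nothing measured here explains why this position responds as it does.

The compounds shown leave open whether the higher number at this position calls for a whole phenyl ring, or whether a smaller group there, such as a methyl group or a single chlorine atom, would also raise it. They also leave open whether an amine or a carboxylic acid carried on the added phenyl ring would move the number back toward that of compound 1 or further away from it.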